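Four Stereoisomeric Iminosugar Acids Against an N-Acetylgalactosaminidase

The compounds below may be only part of what the source reports. "The series", "measured", "known", "first", "only" and "open" are said of these compounds alone.

The measured compounds:
compound 1, `O=C(O)[C@H]1NC[C@H](O)[C@H](O)[C@@H]1O`, 4.5%
compound 2, `O=C(O)[C@H]1NC[C@H](O)[C@@H](O)[C@@H]1O`, 0.2%
compound 3, `O=C(O)[C@@H]1NC[C@H](O)[C@@H](O)[C@H]1O`, 4%

Three stereoisomers of one piperidine carboxylic acid have been tested in an assay for inhibition of alpha-N-acetylgalactosaminidase (Gallus gallus), tested at 1000 uM; on this read-out lower numbers stand for less inhibition and higher numbers for more inhibition at the one concentration tested (going by the name of the read-out). Compound 3 stands second highest of the three numbers, its nearest neighbour being compound 1 and its furthest compound 2; all three numbers lie close to the bottom of the scale.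

The compound still to be measured is compound 4, `O=C(O)[C@@H]1NC[C@@H](O)[C@H](O)[C@H]1O`. It relates to compound 3 as follows: the two compounds have the same atoms and bonds and differ only in configuration as drawn: 2 of 4 stereo elements differ; a stereocentre at a saturated ring carbon is drawn S in compound 3 and R in compound 4; a stereocentre at a saturated ring carbon is drawn R in compound 3 and S in compound 4.

The measured steps are all changes of configuration alone, as shown by the fact that compounds 1 and 2 differ only in the configuration as drawn, the fact that compounds 1 and 3 differ only in the configuration as drawn and (the fact that compounds 2 and 3 differ only in the configuration as drawn). They gave a number 4.3 percentage points lower from compound 1 to compound 2 (within the scatter), a number 0.5 percentage points lower from compound 1 to compound 3 (within the scatter) and a number 3.8 percentage points higher from compound 2 to compound 3 (within the scatter), each within the scatter. Three arrangements of the ring stereocentres, including one step in which three of four centres were inverted, therefore left the read-out essentially unchanged. A further inversion of two centres is accordingly expected to produce no step beyond the scatter, that is a number 1 percentage points lower from compound 3 to compound 4 (within the scatter).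

Compound 4 is therefore estimated to give 3% in this assay, with a range from 0% to 12%.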

Compound 4, a percentage reported as inhibition, at one concentration (the size of the read-out at that concentration, not a potency): 1.3%
The estimate for compound 4 lay 1.7 percentage points above the measured number; the range from low to high includes it.
By their numbers in this assay, from the lowest: compounds 2, 4, 3 and 1 (each within the scatter of the next).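

In this assay, inverting two further centres gave a number 2.7 percentage points lower from compound 3 to compound 4 (within the scatter), so this change of configuration also left the read-out within the scatter. Compound 4 also completes the set's one mirror-image pair, in which all four stereocentres are inverted, and that pair gave a number 1.1 percentage points higher from compound 2 to compound 4 (within the scatter), while the inversion of three centres gave a number 3.2 percentage points lower from compound 1 to compound 4 (within the scatter). No combination of inverted centres among the four compounds moved the number beyond the scatter, and this extends to the complete inversion, where configuration is the only difference: the fact that compounds 2 and 4 differ only in the configuration as drawn

On these data alone, whether a hydroxymethyl group or an acetamide in place of the carboxylic acid would lift the read-out off the bottom of the scale remains open. With a single concentration and a single enzyme, the compounds shown also give no potency for any of the four stereoisomers and say nothing about how they would behave against another enzyme.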